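The compounds below may be only part of what the source reports. "The series", "measured", "known", "first", "only" and "open" are said of these compounds alone.

Measured compounds in the series:

compound 1 `CCC(COc1cccc(C(F)(F)F)c1)OC(=O)NCc1ccccc1` — in an assay for inhibition of zeta-carotene desaturase, chloroplastic/chromoplastic (Capsicum annuum), using a Dixon plot, with a stated time of 8 h (on this read-out lower numbers stand for stronger inhibition and higher numbers for weaker inhibition), compound 1 gives > 100000 nM, a limit of the assay and not a number.
compound 2 `CCC(COc1cccc(Cl)c1)OC(=O)NCc1ccccc1` — in this assay compound 2 gives > 100000 nM, again a limit.
compound 3 `CCC(COc1cccc(C)c1)OC(=O)NCc1ccccc1` — in this assay compound 3 gives > 100000 nM, again a limit.

Compound 1 therefore stands at the upper edge of what this assay reports; no number is known for it, only that its inhibition falls short of the assay's reach. The three measured compounds differ only in the group on the aryloxy ring, and the steps a step that the two limits leave unreadable from compound 1 to compound 2, a step that the two limits leave unreadable from compound 1 to compound 3 and a step that the two limits leave unreadable from compound 2 to compound 3 cannot be read, since every value sits at the limit of > 100000 nM in this assay, at which 3 of the 3 values shown sit. The aryloxy substituent thus gives no readable handle on potency within this set.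

Compound 4 `CCC(COc1cccc(C(F)(F)F)c1)OC(=O)NCc1ccc(Cl)cc1` is the next compound to be measured. It differs from compound 1 by chloro in place of hydrogen on an aromatic carbon. Among the compounds with values here, none of the measured steps touches the benzyl side of the carbamate, so no step bears directly on this change; all three bear only indirectly, in showing the whole scaffold at the limit. With compound 1 at a limit, no direction can be read for the change, and the expected step that the limit leaves unreadable from compound 1 to compound 4 is a guess that compound 4 stays near where compound 1 stands. The estimate for compound 4 in this assay is 150000 nM, with a range from 40000 nM to 1000000 nM, and the most probable outcome is that compound 4 again returns only a limit.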

Compound 4, half-maximal inhibitory concentration: > 100000 nM
Compound 4 was reported as a limit (the forecaster's own chance of this, stated with the estimate: 85%); the middle value does not contradict the limit.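

In this assay compound 4 gives > 100000 nM, a limit and not a number. No step can be read between compound 1 and compound 4, since both sit at the same limit: the limit of > 100000 nM in this assay, at which 4 of the 4 values shown sit.

The compounds shown leave open whether any change to the shared core gives a measurable value in this assay.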